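Shortening the chain on the ring nitrogen of compound 3

The source may report more compounds than this note shows. Statements on the series, on what has been measured and on what is new or still open speak of the compounds shown alone.

Compound 1 `CCCCn1cnc2c(SCc3ccccn3)nc(N)nc21`: 52500 nM
Compound 2 `CCCn1cnc2c(SC(C)C)nc(N)nc21`: 145000 nM
Compound 3 `CCCC(C)n1cnc2c(SCc3ccccn3)nc(N)nc21`: 41700 nM

Of the compounds shown here, three sharing one core have been measured in an assay on isolated protein for binding affinity to Equilibrative nucleoside transporter 1 (Homo sapiens); a higher number here means a weaker inhibitor, a lower number a stronger inhibitor. Compound 3 gives the lowest of the three numbers; its nearest neighbour is compound 1, whose number lies within the scatter of it, while compound 2 stands furthest away, beyond the scatter. Compound 4 `CCCn1cnc2c(SCc3ccccn3)nc(N)nc21` has not yet been measured. It differs from compound 3 in one place: propyl in place of 1-methylbutyl on an aromatic nitrogen.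

Among the measured compounds shown here, one measured step bears on this change. Going a 1.3-fold lower number from compound 1 to compound 3 (0.10 log units; within the scatter) shows that adding a methyl branch at the chain carbon bound to the ring nitrogen did nothing beyond the scatter. Compound 2 also carries a propyl on the ring nitrogen, but it differs from compound 3 in the thioether group as well, so its value cannot be read as a single step; it only shows that with a different thioether the propyl compound gives a high number.

Because a 1.3-fold lower number from compound 1 to compound 3 (0.10 log units; within the scatter) was within the scatter, the shortening to propyl is expected to leave this assay essentially unchanged, with no step beyond the scatter, so a 1.3-fold higher number from compound 3 to compound 4 (0.12 log units; within the scatter). Compound 4 is therefore estimated at 55000 nM, with a range from 25000 nM to 120000 nM.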

Compound 4, half-maximal inhibitory concentration: 91200 nM
The estimate for compound 4 lay 1.7-fold (0.22 log units) below the measured number, and the stated range covers the measured number.
By their numbers in this assay, from the lowest: compounds 3, 1, 4 and 2 (each within the scatter of the next, the first and the last beyond it).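

In this assay, among the compounds shown here, propyl in place of 1-methylbutyl on the aromatic nitrogen gave a 2.2-fold higher number from compound 3 to compound 4 (0.34 log units; beyond the scatter), a modest step and the first change at this position to lie beyond the scatter, whereas adding the methyl branch had given only a 1.3-fold lower number from compound 1 to compound 3 (0.10 log units; within the scatter). The butyl chain of compound 1 does not separate clearly from either neighbour: removing a methyl further along the chain gave a 1.7-fold higher number from compound 1 to compound 4 (0.24 log units; within the scatter), so only the full change from 1-methylbutyl to propyl is resolved. With propyl on the ring nitrogen, (pyridin-2-yl)methyl in place of isopropyl on the sulfur gave a 1.6-fold lower number from compound 2 to compound 4 (0.20 log units; within the scatter), so this change of thioether group is not resolved from the scatter in this pair.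

The data offer no measured explanation for the rise in number on shortening the chain. Going by these compounds, it remains open whether a longer chain on the ring nitrogen, or a chain ending in an amine or a carboxylic acid, would lower the number further, and whether a benzyl group on the sulfur would behave as (pyridin-2-yl)methyl does.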